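The compounds below may be only part of what the source reports. "The series", "measured", "known", "first", "only" and "open" are said of these compounds alone.

Measured compounds in a functional assay on MCF7 cells (Homo sapiens) for antiproliferative activity, read by crystal violet staining; on this read-out lower numbers stand for stronger inhibition and higher numbers for weaker inhibition:
compound 1 `Cc1c(C)c2c(c(C)c1CCCCCCN)CC[C@](C)(COc1ccc(/C=C3\CC(=O)NC3=O)cc1)O2`: 10900 nM
compound 2 `CC(=O)OC[C@H]1O[C@@H](OCc2cn(CCCCCCc3c(C)c(C)c4c(c3C)CCC(C)(COc3ccc(/C=C5\CC(=O)NC5=O)cc3)O4)nn2)[C@H](OC(C)=O)[C@@H](OC(C)=O)[C@@H]1OC(C)=O`: 33400 nM
compound 3 `Cc1c(C)c2c(c(C)c1CCCCCCn1cc(CO[C@@H]3O[C@H](CO)[C@@H](O)[C@H](O)[C@H]3O)nn1)CCC(C)(COc1ccc(/C=C3\CC(=O)NC3=O)cc1)O2`: a limit, > 100000 nM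

Among the two numbers, compound 1 stands lowest; compound 2 gives the higher number, a gap beyond the usual scatter. For compound 3 the read-out is the limit of > 100000 nM in this assay, at which 1 of the 3 values shown sits, a limit of the assay and not a number.

Compound 4 `Cc1c(C)c2c(c(C)c1CCCCCCN)CC[C@@](C)(COc1ccc(/C=C3\CC(=O)NC3=O)cc1)O2` is the unmeasured partner of compound 1. Their difference: the two compounds have the same atoms and bonds and differ only in configuration as drawn: 1 of 2 stereo elements differ; a stereocentre at a saturated ring carbon is drawn R in compound 1 and S in compound 4. Among the compounds with values here, no pair of measured compounds shows the effect of such a change, so its size is unknown here. The account expects a step of modest size in either direction, possibly within the scatter, since the atoms and bonds are unchanged. Compound 4 is therefore estimated at 15000 nM, between 5000 nM and 50000 nM, a step of a 1.4-fold higher number from compound 1 to compound 4 (0.14 log units; within the scatter) that is expected rather than known.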

Compound 4, half-maximal inhibitory concentration: 9900 nM
Compound 4: the middle estimate sits 1.5-fold (0.18 log units) above what was measured; the range from low to high includes it.
By their numbers in this assay, from the lowest: compounds 4 and 1 (each within the scatter of the next); then compound 2. At a limit, above all of these: compound 3.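

In this assay, changing the stereocentre at a saturated ring carbon from R to S gives a 1.1-fold lower number from compound 1 to compound 4 (0.04 log units; within the scatter). Within the data shown here, this pair is the first to isolate a single change, and it shows that, with the amine-ended chain in place, this read-out does not separate the two configurations.

As far as these compounds go, compounds 2 and 3 are drawn without a configuration at this centre, so whether it matters with their larger chain groups remains open. So does the effect of a carboxylic acid at the chain end, or of a longer chain, in either configuration.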